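From Ethoxycarbonyl to Methoxycarbonyl on the Shared Core

A few compounds are considered here, and "the series" means these few. Any claim that something is new, unique, unknown or untested is made for them only; others in the source may bear on it.

In a functional assay on HT-29 cells (Homo sapiens) for antiproliferative activity, read by MTT assay, with a stated time of 72 h (a higher number here means a weaker inhibitor, a lower number a stronger inhibitor), compound 1 (`C=CC(=O)Nc1nc(-c2ccccc2)cs1`) gives 6600 nM as its half-maximal inhibitory concentration. Compound 2 (`C=CC(=O)N(Cc1ccccc1)c1nc(-c2ccccc2)cs1`) carries benzyl on the amide-type nitrogen and gives only a limit of > 30000 nM rather than a number. Compound 3 (`C=CC(=O)N(CC(=O)OCC)c1nc(-c2ccccc2)cs1`) carries (ethoxycarbonyl)methyl there and gives 19000 nM as the higher of the two actual numbers, and the gap to the nearest number is small (a 2.9-fold higher number from compound 1 to compound 3 (0.46 log units; beyond the scatter)).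

Compound 4 (`C=CC(=O)N(CC(=O)OC)c1nc(-c2ccccc2)cs1`) differs from compound 3 in one place (hydrogen in place of methyl on a saturated chain carbon bound to an oxygen next to a carbonyl group), with hydrogen in place of methyl on a saturated chain carbon bound to an oxygen next to a carbonyl group, so that ethoxycarbonyl becomes methoxycarbonyl. Going by the values given here, no measured step touches this end of the chain. The nearest evidence comes from larger replacements on the nitrogen (an at least 4.5-fold higher number from compound 1 to compound 2 (0.65 log units; beyond the scatter)) and (an at least 1.5-fold lower number from compound 2 to compound 3 (0.19 log units; that floor lies within the scatter)), and the floor of the second lies within the scatter. No step beyond the scatter is therefore expected in this assay for this smaller change. The expectation stays close to compound 3 at 19000 nM in this comparison. The estimated step is small (a 1.1-fold lower number from compound 3 to compound 4 (0.02 log units; within the scatter)) and stays within the usual scatter. Compound 4 is expected at about 18000 nM with an estimated range from 9000 nM to 30000 nM in this assay.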

Compound 4, half-maximal inhibitory concentration: > 30000 nM
Compound 4: no number, only a limit; the forecaster's own chance of this, stated with the estimate: 15%; middle value at least 1.6-fold (0.22 log units) from the limit.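

Ethoxycarbonyl to methoxycarbonyl is the first change shown at this end of the chain, and in this assay it gives an at least 1.5-fold higher number from compound 3 to compound 4 (0.19 log units; that floor lies within the scatter), so this small change at the end of the chain has no demonstrated effect beyond the scatter, but a larger one is not excluded. With (methoxycarbonyl)methyl on the amide-type nitrogen the series gives an at least 4.5-fold higher number from compound 1 to compound 4 (0.65 log units; beyond the scatter), which matches the floor of an at least 4.5-fold higher number from compound 1 to compound 2 (0.65 log units; beyond the scatter) and extends a pattern with no exception among the four compounds: each group shown on that nitrogen gives a higher number than hydrogen, by a step beyond the scatter. Compound 4 stands at a limit of the assay and not at a number, as does compound 2, so the step between them cannot be read: the limit of > 30000 nM in this assay, at which 2 of the 4 values shown sit.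

As far as these compounds go, how far compound 4 truly lies from compound 3 remains open, since only a floor within the scatter is available for that step. Also open, from the compounds shown here alone, is how a carboxylic acid, a primary amide or a longer chain at this end of the ester side chain would read in this assay.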